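The source may report more compounds than this note shows. Statements on the series, on what has been measured and on what is new or still open speak of the compounds shown alone.

Compound 2 `CCN1C(=O)CSC1c1cccc(C(=O)NCCCCc2ccccc2)c1` stands lowest of the two numbers in a functional assay on HOS-TE85 cells (Homo sapiens) for inhibition, read by CCK-8 assay, with a stated time of 72 h, tested at 1 uM (on this read-out lower numbers stand for less inhibition and higher numbers for more inhibition at the one concentration tested (going by the name of the read-out)), where compound 2 gives 0%. Within the data shown here, compound 1 `Cc1cccc(N2C(=O)CSC2c2cccc(C(=O)NCCCCc3ccccc3)c2)c1` gives 96% in this assay; the step of a number 96 percentage points lower from compound 1 to compound 2 (beyond the scatter) is the only measured step and is large. Compound 3 `COc1ccc(N2C(=O)CSC2c2cccc(C(=O)NCCCCc3ccccc3)c2)c(OC)c1` differs from compound 2 by 2,4-dimethoxyphenyl in place of ethyl on an amide-type nitrogen in a ring. This change runs against the measured step, a six-membered aromatic ring of carbon only again entering in place of ethyl, so a large rise is expected, a number 80 percentage points higher from compound 2 to compound 3 (beyond the scatter). Compound 3 is therefore estimated at 80%, within a range from 40% to 98%.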

Compound 3, a percentage reported as inhibition, at one concentration (the size of the read-out at that concentration, not a potency): 58%
Beside the measured number, compound 3's estimate is 22 percentage points above it; the range from low to high includes it.
By their numbers in this assay, from the lowest: compound 2; then compound 3; then compound 1.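

On the amide-type nitrogen in the ring, a second six-membered aromatic ring of carbon only also carries inhibition in this assay (a number 58 percentage points higher from compound 2 to compound 3 (beyond the scatter)), so activity over ethyl is not confined to 3-methylphenyl. The aromatic ring's substituents also matter, since 2,4-dimethoxyphenyl in place of 3-methylphenyl gives a clear loss (a number 38 percentage points lower from compound 1 to compound 3 (beyond the scatter)). No evidence on the cause of either step is available here.

Whether a single methoxy group accounts for that loss remains open. Also open, on these data alone, is whether a pyridine ring or a benzyl group on this nitrogen keeps inhibition.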